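Working notes: aryl ketone variation and cell tolerance

The source may hold more compounds than are shown below. What is called first, only, known or untested is meant among the compounds shown, and "the series" means these compounds.

Three measured compounds share one core and differ only in the aryl ring on the carbonyl carbon. Compound 1 `COc1cc(-c2cc(/C=C/C(=O)c3ccc(N)cc3)[nH]n2)cc(OC)c1OC` gives 7510 nM in a functional assay on UACC-62 cells (Homo sapiens) for inhibition, read by sulforhodamine B assay, with a stated time of 48 h; a higher number here means that more compound is tolerated, a lower number that less compound is tolerated. Compound 2 `COc1cc(-c2cc(/C=C/C(=O)c3ccc(Cl)c(Cl)c3)[nH]n2)cc(OC)c1OC` reaches only a limit of this assay, > 100000 nM (the limit of > 100000 nM in this assay, at which 1 of the 3 values shown sits). Compound 3 `COc1ccc(C(=O)/C=C/c2cc(-c3cc(OC)c(OC)c(OC)c3)n[nH]2)cc1OC` gives 5980 nM in this assay. Of the two numbers shown, compound 3 sits lowest, with compound 1 nearest: a 1.3-fold lower number from compound 1 to compound 3 (0.10 log units; within the scatter). The other steps are large: an at least 13-fold higher number from compound 1 to compound 2 (1.12 log units; beyond the scatter) and an at least 16-fold lower number from compound 2 to compound 3 (1.22 log units; beyond the scatter).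

Compound 4 `COc1cc(C(=O)/C=C/c2cc(-c3cc(OC)c(OC)c(OC)c3)n[nH]2)cc(OC)c1OC` carries methoxy in place of hydrogen on an aromatic carbon. For the measured compounds named here, no measured step adds a group to this ring; the steps that bear on the change are those exchanging the ring. The exchange from aminophenyl to dimethoxyphenyl stayed within the scatter, and only the dichloro ring moved the number far. Adding a further methoxy is therefore expected to give no step beyond the scatter, so the step of a 1.0-fold higher number from compound 3 to compound 4 (0.00 log units; within the scatter) is expected to be small. For compound 4 the estimate in this assay is 6000 nM, within a range of 2500 nM to 15000 nM.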

Compound 4, concentration lethal to 50% of the cells: 7600 nM
The estimate for compound 4 lay 1.3-fold (0.10 log units) below the measured number; measured number inside the range.
By their numbers in this assay, from the lowest: compounds 3, 1 and 4 (each within the scatter of the next). At a limit, above all of these: compound 2.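

In this assay, for the compounds shown here, the one step that adds a group to this ring, methoxy in place of hydrogen on an aromatic carbon ortho to a methoxy group, gives a 1.3-fold higher number from compound 3 to compound 4 (0.10 log units; within the scatter). This position therefore accepts a further methoxy with no step beyond the scatter, a result the earlier whole-ring exchanges could not show, and compounds 3, 1 and 4 each lie within the scatter of the next. Nothing measured here accounts for this step.

The compounds shown leave open whether a hydroxy group, an amine or a carboxylic acid on this same carbon would also stay within the scatter. Also open, going by these compounds, is whether a single chlorine would move the number as far as the dichlorophenyl ring of compound 2, whose reading is a limit.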